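This account rests on a few compounds, and the source may have more. Where it says the series, first, only, none or still open, it means among the compounds named here.

Of the compounds shown here, two have been tested in an assay on brain for binding affinity to adenosine receptor A1 (Rattus norvegicus) (a lower number here means a stronger inhibitor, a higher number a weaker inhibitor), so far. Compound 1 `C=C[C@H]1O[C@@H](n2cnc3c(NOC)nc(Cl)nc32)[C@H](O)[C@@H]1O` gives 1230 nM in this assay. Compound 2 `O[C@@H]1[C@H](O)[C@@H](c2ccon2)O[C@H]1n1cnc2c(NCc3cccc(I)c3)nc(Cl)nc21` gives 1900 nM, the highest of the two numbers, yet it lies within the scatter of compound 1, so the two cannot be told apart. Compound 3 `CONc1nc(Cl)nc2c1ncn2[C@@H]1O[C@H](c2ccon2)[C@@H](O)[C@H]1O` is compound 2 with methoxy in place of 3-iodobenzyl on a nitrogen on an aromatic ring. Within the data shown here, no measured pair shows this exact change, so its effect is unknown. Compound 1 carries the methoxyamino group and sits close to compound 2, so the step from compound 2 to compound 3 is expected to be a 1.3-fold lower number from compound 2 to compound 3 (0.10 log units; within the scatter), within the scatter. Compound 3 is therefore estimated at 1500 nM, between 400 nM and 6000 nM.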

Compound 3, inhibition constant: 620 nM
The estimate for compound 3 lay 2.4-fold (0.38 log units) above the measured number; measured number inside the range.
By their numbers in this assay, from the lowest: compounds 3, 1 and 2 (each within the scatter of the next, the first and the last beyond it).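

On a nitrogen on an aromatic ring, methoxy in place of 3-iodobenzyl gives a 3.1-fold lower number from compound 2 to compound 3 (0.49 log units; beyond the scatter) in this assay, so with 1,2-oxazol-3-yl present, the modest gain comes with the smaller group, which has no ring and no iodine. With the methoxyamino group held fixed, 1,2-oxazol-3-yl in place of vinyl on a saturated ring carbon gives a 2.0-fold lower number from compound 1 to compound 3 (0.30 log units; within the scatter), so these two groups cannot be told apart. Nothing available explains either step. On these data alone, it remains open how an ethoxy group or a plain benzyl group would compare on that nitrogen, and whether the methoxy step would hold with vinyl in place of 1,2-oxazol-3-yl.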